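Benzyl ester series: chloro for methyl at the aromatic ring

This account rests on a few compounds, and the source may have more. Where it says the series, first, only, none or still open, it means among the compounds named here.

Measured compounds:
Compound 1 `O=C(OCc1ccccc1)c1cccc(=O)[nH]1`, 69000 nM
Compound 2 `O=C(OCc1ccccc1Br)c1cccc(S)n1`, > 150000 nM
Compound 3 `Cc1ccc(COC(=O)c2cccc(=O)[nH]2)cc1`, 68000 nM

The read-out throughout is an assay on isolated protein for inhibition of matrix metalloproteinase-9 (Homo sapiens); on this read-out lower numbers stand for stronger inhibition and higher numbers for weaker inhibition. Compound 1 gives 69000 nM in this assay. For compound 2 the value is a limit of this assay, > 150000 nM, not a number; the limit is the limit of > 150000 nM in this assay, at which 1 of the 3 values shown sits. Compound 3 gives 68000 nM, the lowest of the two numbers shown, but its nearest neighbour, compound 1, is within the scatter of it, so no order between the two can be read. Going by the values given here, the only single-point step among the measured compounds is a 1.0-fold lower number from compound 1 to compound 3 (0.01 log units; within the scatter), a change that leaves the number where it was.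

Compound 4 `O=C(OCc1ccc(Cl)cc1)c1cccc(=O)[nH]1` is not yet measured. It differs from compound 3 as follows: chloro in place of methyl on an aromatic carbon. Among the compounds with values here, the one step that bears on it, from compound 1 to compound 3, changed the same aromatic carbon and left the number unmoved within the scatter. With no further data on that position, no step beyond the scatter is expected in this assay, in either direction. Compound 4 is therefore estimated at 65000 nM, within 30000 nM to 140000 nM, which means an expected step of a 1.0-fold lower number from compound 3 to compound 4 (0.02 log units; within the scatter).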

Compound 4, half-maximal inhibitory concentration: 68000 nM
Beside the measured number, compound 4's estimate is 1.0-fold (0.02 log units) below it, and the stated range covers the measured number.
By their numbers in this assay, from the lowest: compounds 3, 4 and 1 (each within the scatter of the next). At a limit, above all of these: compound 2.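

In this assay the new result gives no change at the digits printed from compound 3 to compound 4 (within the scatter) for chloro in place of methyl, and a 1.0-fold lower number from compound 1 to compound 4 (0.01 log units; within the scatter) for chloro in place of hydrogen, both on the aromatic carbon para to a large group. Going by these compounds alone, until now methyl was the only group at this carbon with a number; with chloro there, compounds 1, 3 and 4 all lie within the scatter of one another, so no order among hydrogen, methyl and chloro can be read at this position. Nothing measured in this set gives a reason for these flat steps.

As far as these compounds go, whether any group at this carbon moves the number at all stays open, since a charged or larger group such as an amine, a carboxylic acid or a longer chain has no value here to set against hydrogen, methyl and chloro. Compound 2 carries the limit > 150000 nM rather than a number and differs from compound 1 in more than one place, so it separates none of its changes and leaves the role of the rest of the core unresolved.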